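Ring size of the chain amine: compound 3 to compound 4

This account rests on a few compounds, and the source may have more. Where it says the series, first, only, none or still open, it means among the compounds named here.

Compound 3 `COc1cc2c(Nc3nc4ccc(C(=O)Nc5c(C)cc(C)cc5C)cc4s3)ncnc2cc1OCCCN1CCCCC1` gives 16900 nM in a functional assay on HCT-116 cells (Homo sapiens) for cytotoxicity, read by WST assay, with a stated time of 72 h (a lower number here means a stronger inhibitor, a higher number a weaker inhibitor), the second highest of the three numbers in hand. Compound 1 `COc1cc2c(Nc3nc4ccc(C(=O)Nc5c(C)cc(C)cc5C)cc4s3)ncnc2cc1OCCCN1CCCCC1C` gives 5600 nM, and compound 2 `COc1cc2c(Nc3nc4ccc(C(=O)Nc5c(C)cccc5Cl)cc4s3)ncnc2cc1OCCCN1CCCC1` gives 63800 nM. Compound 4 `COc1cc2c(Nc3nc4ccc(C(=O)Nc5c(C)cc(C)cc5C)cc4s3)ncnc2cc1OCCCN1CCCC1` differs from compound 3 by pyrrolidin-1-yl in place of piperidin-1-yl on a saturated chain carbon, three bonds along the chain from an oxygen on an aromatic ring. For the measured compounds named here, no measured step covers this exact change. Going by the values given here, the one step in the amine region, a 3.0-fold higher number from compound 1 to compound 3 (0.48 log units; beyond the scatter), was modest. Among the compounds with values here, compound 2 carries the pyrrolidine but also differs at the anilide, so its number and that of compound 3 form no single step. With only a modest change seen in this region, a step of a 1.5-fold higher number from compound 3 to compound 4 (0.17 log units; within the scatter) is expected for compound 4, possibly within the scatter. The estimate for compound 4 is 25000 nM, with a range from 9000 nM to 70000 nM.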

Compound 4, half-maximal inhibitory concentration: 5800 nM
Beside the measured number, compound 4's estimate is 4.3-fold (0.63 log units) above it, and the stated range ends above it.
By their numbers in this assay, from the lowest: compounds 1 and 4 (each within the scatter of the next); then compound 3; then compound 2.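

In this assay, the ring size of the chain amine alone moves the number: pyrrolidin-1-yl in place of piperidin-1-yl gives a 2.9-fold lower number from compound 3 to compound 4 (0.46 log units; beyond the scatter) on an unchanged anilide. Pyrrolidin-1-yl and 2-methylpiperidin-1-yl stand level, with a 1.0-fold higher number from compound 1 to compound 4 (0.02 log units; within the scatter) as the step between them. With pyrrolidin-1-yl held fixed, 2,4,6-trimethylphenyl in place of 2-chloro-6-methylphenyl gives an 11-fold lower number from compound 2 to compound 4 (1.04 log units; beyond the scatter) and shows that the anilide also carries weight.

No evidence bears on these differences. Open, on these data alone, is whether a morpholine ring or a dimethylamino group on the propyl chain would fit these numbers.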